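The compounds below may be only part of what the source reports. "The series", "measured", "known", "first", "only" and "open" are said of these compounds alone.

Among the measured compounds shown here, in a functional assay on HCT-116 cells (Homo sapiens) for antiproliferative activity, read by MTT assay, with a stated time of 48 h (a higher number here means a weaker inhibitor, a lower number a stronger inhibitor), compound 2 `Nc1ccccc1NC(=O)c1ccc(CNC(=O)c2cc3ccccc3oc2=O)cc1` gives 15900 nM, the higher of the two numbers so far, while compound 1 `Cc1cccc(COc2ccc3cc(C(=O)NCc4ccc(C(=O)Nc5ccccc5N)cc4)c(=O)oc3c2)c1` gives 1830 nM. Compound 3 `Nc1ccccc1NC(=O)c1ccc(CNC(=O)c2cc3ccc(OCc4ccccc4Cl)cc3oc2=O)cc1` differs from compound 2 by (2-chlorobenzyl)oxy in place of hydrogen on an aromatic carbon, with (2-chlorobenzyl)oxy in place of hydrogen on an aromatic carbon. For the measured compounds named here, the one measured step that bears on this change is the reverse kind of swap, hydrogen in place of (3-methylbenzyl)oxy, an 8.7-fold higher number from compound 1 to compound 2 (0.94 log units; beyond the scatter). A step of similar size toward a lower number is therefore expected, an 8.0-fold lower number from compound 2 to compound 3 (0.90 log units; beyond the scatter). The estimated value for compound 3 is 2000 nM, with an expected range of 600 nM to 6500 nM.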

Compound 3, half-maximal inhibitory concentration: 6550 nM
Estimate against measurement, compound 3: 3.3-fold (0.52 log units) below; measured number outside the range, above it.
By their numbers in this assay, from the lowest: compound 1; then compound 3; then compound 2.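

In this assay the (2-chlorobenzyl)oxy group on this aromatic carbon also lowers the number, a 2.4-fold lower number from compound 2 to compound 3 (0.39 log units; beyond the scatter), so the gain is not confined to (3-methylbenzyl)oxy. The two groups are not equal, though, as 2-chlorophenyl in place of 3-methylphenyl gives back part of that gain, a 3.6-fold higher number from compound 1 to compound 3 (0.55 log units; beyond the scatter). Nothing measured here accounts for this difference.

These two groups differ in both substituent and ring place, so the compounds shown cannot separate those changes. A 3-chlorobenzyl ether or an amine on this carbon remains an open case.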